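This account rests on a few compounds, and the source may have more. Where it says the series, first, only, none or still open, it means among the compounds named here.

Working notes on the series.

Compound 1 `CCC1C(=O)N(C)c2cnc(Nc3ccc(S(N)(=O)=O)cc3)nc2N1C` is the reference point. Going by the values given here, in an assay on Sf9 cells for inhibition of serine/threonine-protein kinase 4 (Homo sapiens), read by luminescence and ADP-Glo, with a stated time of 1 h, in the presence of a further agent that is not named here (on this read-out higher numbers stand for weaker inhibition and lower numbers for stronger inhibition), compound 1 gives 479 nM, the highest of the two numbers so far; the nearest is compound 2 `CN1C(=O)C(c2ccccc2)N(C)c2nc(Nc3ccc(S(N)(=O)=O)cc3)ncc21`, which in this assay gives 383 nM. Among the compounds with values here, the only measured step, a 1.3-fold lower number from compound 1 to compound 2 (0.10 log units; within the scatter), changes the ethyl group on the saturated ring carbon for a phenyl ring and leaves the read-out within the scatter.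

Compound 3 `COc1ccccc1C1C(=O)N(C)c2cnc(Nc3ccc(S(N)(=O)=O)cc3)nc2N1C` is the next candidate. It differs from compound 1 as follows: 2-methoxyphenyl in place of ethyl on a saturated ring carbon. Within the data shown here, the step from compound 1 to compound 2 bears directly on this change, since it swaps the same ethyl group for an aromatic ring at the same place, and it was small; the added methoxy group has no precedent here. A step of about the same size, or none beyond the scatter, is therefore expected in this assay.

The step of a 1.3-fold lower number from compound 1 to compound 3 (0.12 log units; within the scatter) is the expected outcome. Compound 3 is estimated at 360 nM in this assay, with a range from 120 nM to 1100 nM.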

Compound 3, half-maximal inhibitory concentration: 251 nM
Compound 3: middle estimate off by 1.4-fold (0.16 log units), on the high side, within the range that was stated.
By their numbers in this assay, from the lowest: compounds 3, 2 and 1 (each within the scatter of the next).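

In this assay the step of a 1.9-fold lower number from compound 1 to compound 3 (0.28 log units; within the scatter) shows that 2-methoxyphenyl can stand in place of ethyl on this saturated ring carbon without leaving the scatter, so a substituted aromatic ring is tolerated here as well as an unsubstituted one. Going by these compounds alone, the step of a 1.5-fold lower number from compound 2 to compound 3 (0.18 log units; within the scatter) gives the first reading of a change on that aromatic ring itself: methoxy in place of hydrogen on an aromatic carbon also stays within the scatter. No supporting data bear on why either step has this size.

As far as these compounds go, whether an amine or a carboxylic acid on the phenyl ring, or a longer chain such as butyl in place of ethyl, would give a step beyond the scatter remains open. So far, no change at this position has been separated from the scatter.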